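The source may hold more compounds than are shown below. What is called first, only, known or untested is meant among the compounds shown, and "the series" means these compounds.

For the measured compounds named here, compound 1 `O=C1C(O)=C(C(c2ccc([N+](=O)[O-])cc2)c2c[nH]c3ccccc23)C(=O)c2ccccc21` is the first of the three compounds. In a toxicity assay (Homo sapiens) for cytotoxicity, read by MTT assay, with a stated time of 48 h (a higher number here means a weaker inhibitor, a lower number a stronger inhibitor), compound 1 gives > 200000 nM, which is a limit of the assay and not a number. Compound 2 `O=C1C(O)=C(C(c2cccc([N+](=O)[O-])c2)c2c(-c3ccccc3)[nH]c3ccccc23)C(=O)c2ccccc21` in this assay gives 13400 nM, the only number shown. The other value shown, that of compound 1, is a limit (the limit of > 200000 nM in this assay, at which 1 of the 2 values shown sits). Compound 3 `O=C1C(O)=C(C(c2ccc([N+](=O)[O-])cc2)c2c(-c3ccccc3)[nH]c3ccccc23)C(=O)c2ccccc21` differs from compound 2 by 4-nitrophenyl in place of 3-nitrophenyl on a saturated chain carbon bound to an aromatic carbon and a double-bonded ring carbon. No step between measured compounds is shown, so this change has no measured precedent here; a modest weakening beyond the scatter is expected, a 1.9-fold higher number from compound 2 to compound 3 (0.27 log units; within the scatter). Compound 3 is expected to give 25000 nM, with a range from 8000 nM to 150000 nM.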

Compound 3, half-maximal inhibitory concentration: 14200 nM
Estimate against measurement, compound 3: 1.8-fold (0.25 log units) above; measured number inside the range.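

In this assay, 4-nitrophenyl and 3-nitrophenyl on this saturated chain carbon cannot be told apart, with a 1.1-fold higher number from compound 2 to compound 3 (0.03 log units; within the scatter). Phenyl in place of hydrogen on an aromatic carbon is the large change, with an at least 14-fold lower number from compound 1 to compound 3 (1.14 log units; beyond the scatter). Compound 1 stands at a limit of the assay and not at a number: the limit of > 200000 nM in this assay, at which 1 of the 3 values shown sits.

The compounds shown leave open what an amine or a carboxylic acid in place of the nitro group would give in this assay. They also leave open whether a methyl in place of that phenyl would give a step of similar size.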